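The compounds below may be only part of what the source reports. "The series", "measured", "known", "first", "only" and "open" are said of these compounds alone.

Measured in an assay on CHO cells for displacement of a labelled ligand from adenosine receptor A1 (Homo sapiens), read by scintillation counting, with a stated time of 60 min, tested at 10 uM; a higher number here means more inhibition at the concentration tested (going by the name of the read-out), a lower number less inhibition:
compound 1, `O=C(NC1CCCC1)c1cc2ccccc2oc1=O`, 16%
compound 2, `COc1cccc2cc(C(=O)NC3CCCC3)c(=N)oc12`, > 70%, a limit of the assay
compound 3, `O=C(NCCCO)c1cc2ccccc2oc1=O`, 24%

Compound 3 and compound 1 give numbers within the scatter of each other: the step of a number 8 percentage points higher from compound 1 to compound 3 (within the scatter) does not separate them. Compound 2 is reported only as a limit, (the limit of > 70% in this assay, at which 1 of the 3 values shown sits).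

Compound 4, `O=C(NCCCO)c1cc2cccc(O)c2oc1=O`, differs from compound 3 by hydroxy in place of hydrogen on an aromatic carbon. Within the data shown here, no measured step concerns a change on the aromatic ring: the only measured step exchanges the group on the amide-type nitrogen and stays within the scatter, and compound 2 differs from compound 3 in more than one place, so its limit cannot be tied to the ring alone. There is thus no measured basis for a shift in either direction; the step to compound 4 is expected to be small, a number 4 percentage points higher from compound 3 to compound 4 (within the scatter), with the chance of a larger change left open. Compound 4 is estimated at 28%, between 8% and 55%.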

Compound 4, a percentage reported as inhibition, at one concentration (the size of the read-out at that concentration, not a potency): 18%
Compound 4: the middle estimate sits 10 percentage points above what was measured; the measured number falls inside the stated range.
By their numbers in this assay, from the lowest: compounds 1, 4 and 3 (each within the scatter of the next). At a limit, above all of these: compound 2.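

In this assay, among these compounds, compound 4 gives the first reading of a change on the aromatic ring of the shared core: hydroxy in place of hydrogen on an aromatic carbon, ortho to a fused ring, gives a number 6 percentage points lower from compound 3 to compound 4 (within the scatter). With the 3-hydroxypropyl group kept on the amide-type nitrogen, this position therefore takes a hydroxy without a number that can be told apart from that of compound 3. Nothing at hand bears on a cause for this step.

Compound 2 differs from compound 4 in more than one place and stands only at a limit, so it does not settle what the ring change alone can do: the limit of > 70% in this assay, at which 1 of the 4 values shown sits. From the compounds shown here alone, it remains open whether an amine or a carboxylic acid on this aromatic carbon, or a longer chain on the amide-type nitrogen, would give a step beyond the scatter.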